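The source may report more compounds than this note shows. Statements on the series, on what has been measured and on what is new or still open speak of the compounds shown alone.

Among the compounds with values here, compound 2 `CCOc1ccc2c(Cl)ccnc2c1` gives 3460 nM in a functional assay on SK-OV-3 cells (Homo sapiens) for cytotoxicity, read by MTT assay, with a stated time of 48 h (a lower number here means a stronger inhibitor, a higher number a weaker inhibitor), and stands as the only numeric value among the two compounds measured. Compound 1 `CCCCCCOc1ccc2c(Cl)ccnc2c1` reaches only a limit in this assay, > 10000 nM. Within the data shown here, the single measured step is an at least 2.8-fold lower number from compound 1 to compound 2 (0.46 log units; beyond the scatter); it rests on (the limit of > 10000 nM in this assay, at which 1 of the 2 values shown sits), so its true size is unknown beyond that. Compound 3 `C=CCOc1ccc2c(Cl)ccnc2c1` is to be measured in this assay and differs from compound 2 by vinyl in place of methyl on a saturated chain carbon bound to an oxygen on an aromatic ring, that is ethoxy to allyloxy. The measured step bears on this in the opposite sense: dropping butyl two bonds along the chain from the oxygen gave the at least modest gain from compound 1 to compound 2, and lengthening the chain again, now as a vinyl, may give back a small part of it. The estimate for compound 3 is 4500 nM, range 1800 nM to 12000 nM, a step of a 1.3-fold higher number from compound 2 to compound 3 (0.11 log units; within the scatter) expected to be small, near the edge of the scatter.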

Compound 3, half-maximal inhibitory concentration: 4030 nM
Compound 3: the middle estimate sits 1.1-fold (0.05 log units) above what was measured; measured number inside the range.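

In this assay, ethoxy and allyloxy are not told apart: a 1.2-fold higher number from compound 2 to compound 3 (0.07 log units; within the scatter). This position on the saturated chain carbon bound to the oxygen therefore accepts vinyl in place of methyl, including a double bond outside the aromatic rings, with no step beyond the scatter, which the earlier pair of compounds could not show. Allyloxy also keeps the gap to the long chain, with an at least 2.4-fold lower number from compound 1 to compound 3 (0.39 log units; beyond the scatter), and the true size of this step stays open: the limit of > 10000 nM in this assay, at which 1 of the 3 values shown sits.

The compounds shown leave open whether the double bond plays any part here, and a saturated propoxy chain would separate it from chain length. They also leave open how a butoxy chain, or a terminal amine or carboxylic acid on the chain, would read in this assay.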